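The source may hold more compounds than are shown below. What is called first, only, known or untested is meant among the compounds shown, and "the series" means these compounds.

In an assay (Cricetulus griseus) for inhibition of aldehyde dehydrogenase, mitochondrial (Homo sapiens) (a higher number here means a weaker inhibitor, a lower number a stronger inhibitor), compound 1 `CCOC(=O)COc1ccc2c(=O)c(-c3ccc(O)cc3)coc2c1` gives 130 nM, and compound 2 `CCOC(=O)CCCCOc1ccc2c(=O)c(-c3ccc(O)cc3)coc2c1` gives 240 nM. Within the data shown here, the one measured step, a 1.8-fold higher number from compound 1 to compound 2 (0.27 log units; within the scatter), stays within the scatter, so compound 2 stands together with compound 1 on this assay rather than apart from it; these two numbers are all that the series shows so far.

Compound 3 `NCCCCOc1ccc2c(=O)c(-c3ccc(O)cc3)coc2c1` differs from compound 2 by amino in place of ethoxycarbonyl on a saturated chain carbon, four bonds along the chain from an oxygen on an aromatic ring. Among the measured compounds shown here, no measured step touches an exchange of this kind; the step of a 1.8-fold higher number from compound 1 to compound 2 (0.27 log units; within the scatter) concerns only the length of the chain and leaves the ester in place, so it offers no direction for the change to the amino group. With nothing in the data pointing either way, the working expectation for compound 3 in this assay is a step of no change at the digits printed from compound 2 to compound 3 (within the scatter), not beyond the scatter, with a wide allowance on either side. Compound 3 is therefore estimated at 240 nM, within 80 nM to 800 nM.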

Compound 3, half-maximal inhibitory concentration: 250 nM
Estimate against measurement, compound 3: 1.0-fold (0.02 log units) below; measured number inside the range.
By their numbers in this assay, from the lowest: compounds 1, 2 and 3 (each within the scatter of the next).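

In this assay the exchange of ethoxycarbonyl for amino gives a 1.0-fold higher number from compound 2 to compound 3 (0.02 log units; within the scatter) on the saturated chain carbon, four bonds along the chain from an oxygen on an aromatic ring, so this read-out does not separate the two groups at this place, even though five heavy atoms give way to one. The wider exchange of ethoxycarbonyl for 3-aminopropyl gives a 1.9-fold higher number from compound 1 to compound 3 (0.28 log units; within the scatter) and leaves all three compounds together. No measurement bears on why the number holds across these exchanges.

As far as these compounds go, whether a carboxylic acid, an amide or a longer chain at this place would stay with these three remains open. Also open is whether amino on a shorter chain would read the same, since the chain length and the amino group change together between the compounds shown.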